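Hydroxy in Place of Ethyl on Compound 2

A few compounds are considered here, and "the series" means these few. Any claim that something is new, unique, unknown or untested is made for them only; others in the source may bear on it.

Among the three measured compounds, compound 2 `CCc1cnc(N2CCC(c3coc4c(N5CCc6cc(S(C)(=O)=O)ccc65)ncnc34)CC2)nc1` stands lowest: in a functional assay on cells for agonist activity at Glucose-dependent insulinotropic receptor (Homo sapiens), read by a luciferase reporter, with a stated time of 4 h (on this read-out lower numbers stand for an effect already at smaller amounts and higher numbers for an effect only at larger amounts of compound), compound 2 gives 41 nM. Nearest to it is compound 3 `CC(C)(C)OC(=O)N1CCC(c2coc3c(Nc4ccc(S(C)(=O)=O)cc4F)ncnc23)CC1`, which in this assay gives 129 nM. Furthest away is compound 1 `Cc1cnc(N2CCC(c3coc4c(N5CCc6cc(S(C)(=O)=O)ccc65)ncnc34)CC2)nc1`, which in this assay gives 252 nM. Only one measured step joins two of these compounds in a single place, namely a 6.1-fold lower number from compound 1 to compound 2 (0.79 log units; beyond the scatter), a methyl in place of hydrogen on a saturated chain carbon bound to an aromatic carbon. For the measured compounds named here, compound 3 shares no single-place step with compound 2, so only their two values can be set side by side.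

Compound 4 `CS(=O)(=O)c1ccc2c(c1)CCN2c1ncnc2c(C3CCN(c4ncc(O)cn4)CC3)coc12` differs from compound 2 by hydroxy in place of ethyl on an aromatic carbon of the six-membered ring, two atoms from the ring nitrogen and para to a large group; read one bond further out, 5-ethylpyrimidin-2-yl becomes 5-hydroxypyrimidin-2-yl. Going by the values given here, the step that bears on this is the one from compound 1 to compound 2, where lengthening the chain on that carbon lowered the number; the new change runs the other way and removes the chain altogether. A higher number is therefore expected for compound 4, a 9.8-fold higher number from compound 2 to compound 4 (0.99 log units; beyond the scatter). Compound 4 is estimated at 400 nM, with a range from 80 nM to 2000 nM.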

Compound 4, half-maximal effective concentration: 391 nM
Compound 4: middle estimate off by 1.0-fold (0.01 log units), on the high side; the measured number falls inside the stated range.
By their numbers in this assay, from the lowest: compound 2; then compounds 3, 1 and 4 (each within the scatter of the next, the first and the last beyond it).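

The earlier compounds shown here carried only carbon chains on this aromatic carbon of the six-membered ring, so they could not show what a group joined through oxygen does at this position. In this assay the change from 5-ethylpyrimidin-2-yl to 5-hydroxypyrimidin-2-yl gives a 9.5-fold higher number from compound 2 to compound 4 (0.98 log units; beyond the scatter) and thus gives up what ethyl held over methyl, while the comparison with the methyl group gives a 1.6-fold higher number from compound 1 to compound 4 (0.19 log units; within the scatter) and leaves hydroxy and methyl indistinguishable on this read-out. Among the three groups seen here, only ethyl therefore stands apart from the other two, and nothing available explains this result or ties it to the hydrogen-bond donor and acceptor that enter with hydroxy.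

Going by these compounds, what stays open is whether the higher number of compound 4 relative to compound 2 follows from the loss of the two-carbon chain or from the oxygen itself, a question that a methoxy or ethoxy group on the same carbon would address. Equally open, on these data alone, is whether the trend from methyl to ethyl continues to a propyl chain or a longer one, and how an amine would compare with hydroxy at this position.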